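The source may hold more compounds than are shown below. What is called first, only, known or untested is meant among the compounds shown, and "the series" means these compounds.

Among the compounds with values here, compound 1 `CC1=NN(c2ccc(C)cc2)C(=O)C12C=CC(=O)C=C2c1ccc(C)cc1` is one of two compounds measured in a functional assay on HCT-116 cells (Homo sapiens) for antiproliferative activity, read by CCK-8 assay, with a stated time of 72 h; a lower number here means a stronger inhibitor, a higher number a weaker inhibitor; in this assay compound 1 gives 9710 nM. The other measured compound, compound 2 `CC1=NN(c2ccc(C)cc2)C(=O)C12C=CC(=O)C=C2c1ccccc1`, gives 16500 nM in this assay. The only step shown, a 1.7-fold higher number from compound 1 to compound 2 (0.23 log units; within the scatter), lies within the scatter, so compound 1 has the lowest of the two numbers but cannot be set apart on that basis. Compound 3 `CC1=NN(c2ccc(Cl)cc2)C(=O)C12C=CC(=O)C=C2c1ccc(C)cc1` differs from compound 1 by chloro in place of methyl on an aromatic carbon. Within the data shown here, no measured step bears on this change: the single step available, a 1.7-fold higher number from compound 1 to compound 2 (0.23 log units; within the scatter), concerns a different change, hydrogen in place of methyl on an aromatic carbon, and is itself within the scatter. With nothing pointing in either direction, compound 3 is expected to give much the same number as compound 1, a step of a 1.1-fold lower number from compound 1 to compound 3 (0.03 log units; within the scatter) that stays within the scatter. Compound 3 is therefore estimated at 9000 nM in this assay, within a range from 3000 nM to 27000 nM.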

Compound 3, half-maximal inhibitory concentration: 10300 nM
Compound 3: the middle estimate sits 1.1-fold (0.06 log units) below what was measured; measured number inside the range.
By their numbers in this assay, from the lowest: compounds 1, 3 and 2 (each within the scatter of the next).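

In this assay, within the data shown here, the change from 4-methylphenyl to 4-chlorophenyl gives a 1.1-fold higher number from compound 1 to compound 3 (0.03 log units; within the scatter), so chloro in place of methyl at this position, para to a large group, produces no step that can be told from the scatter. This is a different 4-methylphenyl group from the one that loses its methyl in compound 2, so the result adds a second site on the core of compound 1 where a single substitution leaves the number within the scatter. No available evidence accounts for this result.

The compounds shown leave open whether a group such as an amine, a carboxylic acid or a methoxy group at this position would move the number beyond the scatter. They also leave open how chloro would read on the other aromatic ring.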